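Methoxy loss in the nitrile member of the series

The compounds below may be only part of what the source reports. "The series", "measured", "known", "first", "only" and "open" are said of these compounds alone.

Values in a functional assay on HepG2 cells (Homo sapiens) for inhibition, read by MTT assay, with a stated time of 24 h (on this read-out lower numbers stand for stronger inhibition and higher numbers for weaker inhibition), as follows
compound 1 (`Cc1ccc(C(=O)NCC(=O)N/N=C/c2ccccc2OCc2ccccc2Cl)cc1`) gives 13400 nM as a number
compound 2 (`O=C(CNC(=O)c1ccc(-c2ccccc2)cc1)N/N=C/c1ccccc1OCc1ccccc1Cl`) gives > 50000 nM as a limit
compound 3 (`COc1ccc(/C=N/NC(=O)CNC(=O)c2ccc(C#N)cc2)c(OCc2ccccc2Cl)c1`) gives > 50000 nM as a limit

Compound 3 gives > 50000 nM in this assay and this is a limit of the assay, not a number. It therefore stands at the limit of > 50000 nM in this assay, at which 2 of the 3 values shown sit, and has no exact place in the series. Compound 4 (`N#Cc1ccc(C(=O)NCC(=O)N/N=C/c2ccccc2OCc2ccccc2Cl)cc1`) differs from it by one change (hydrogen in place of methoxy on an aromatic carbon) with hydrogen in place of methoxy on an aromatic carbon.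

For the measured compounds named here, the one measured step is an at least 3.7-fold higher number from compound 1 to compound 2 (0.57 log units; beyond the scatter) and it concerns phenyl in place of methyl on an aromatic carbon. Going by the values given here, that is a different change from the one here, so no measured step tests the methoxy directly. Compound 1 also has no methoxy and gives 13400 nM as a number, so a number for compound 4 is possible. Compound 2 also has no methoxy and reports only a limit, so the limit may well return.

The expected move is toward a lower number, of uncertain size, and the estimated step is an at least 1.6-fold lower number from compound 3 to compound 4 (0.22 log units; that floor lies within the scatter) in this series. The estimate for compound 4 is 30000 nM with an expected range of 11000 nM to 60000 nM in this assay for now.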

Compound 4, half-maximal inhibitory concentration: > 50000 nM
Compound 4: a limit, no number; the forecaster's own chance of this, stated with the estimate: 45%; middle value at least 1.6-fold (0.22 log units) away from the limit.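

With the methoxy gone, the nitrile member stays at a limit: in this assay compound 4 gives > 50000 nM, which is a limit of the assay and not a number. The steps to compound 4 from compound 3 and from compound 2 cannot be read, since both ends of each are limits, so hydrogen in place of methoxy has no measured size here. The one readable comparison concerns the other substituent, where a cyano replaces the methyl, with an at least 3.7-fold higher number from compound 1 to compound 4 (0.57 log units; beyond the scatter), which leaves compound 1 as the only member shown with a number, and the rest of the series gathers at one ceiling: the limit of > 50000 nM in this assay, at which 3 of the 4 values shown sit.

The compounds shown hold no pair in which the methoxy change runs between two numbers, so what this change does to the methyl member, compound 1, stays open. Also open, as far as these compounds go, is how an amine or a carboxylic acid would read in place of the cyano, and whether any such group brings the series back to a number.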